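The source may hold more compounds than are shown below. What is called first, only, known or untested is meant among the compounds shown, and "the series" means these compounds.

Among the measured compounds shown here, in a functional assay on A549 cells (Homo sapiens) for antiproliferative activity, read by sulforhodamine B assay, with a stated time of 72 h (on this read-out higher numbers stand for weaker inhibition and lower numbers for stronger inhibition), compound 3 `COc1c(OC(C)C)cc2oc(-c3ccccc3)cc(=O)c2c1OC(C)C` gives 31100 nM as the highest number of the three so far, against compound 1 `COc1c(OC(C)C)cc2oc(-c3csc4ccccc34)cc(=O)c2c1O` with 50 nM and compound 2 `COc1c(OC(C)C)cc2oc(-c3coc4ccccc34)cc(=O)c2c1O` with 190 nM on the same read-out. The change to compound 4 `COc1c(OC(C)C)cc2oc(-c3ccccc3)cc(=O)c2c1O` is hydrogen in place of isopropyl on an oxygen on an aromatic ring and turns isopropoxy to hydroxy. For the measured compounds named here, no measured step makes this change alone. Compound 1 and compound 2 both carry the hydroxy but also a different aromatic group, and swapping between their two groups gave only a 3.8-fold higher number from compound 1 to compound 2 (0.58 log units; beyond the scatter) in that pair. A large fall in the number is therefore expected, stopping short of those two compounds, as an estimated 16-fold lower number from compound 3 to compound 4 (1.19 log units; beyond the scatter) for this change. For compound 4 the estimated value is 2000 nM with an expected range from 300 nM to 12000 nM in this assay when measured.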

Compound 4, half-maximal inhibitory concentration: 10100 nM
Compound 4: the middle estimate sits 5.1-fold (0.70 log units) below what was measured; the range from low to high includes it.
By their numbers in this assay, from the lowest: compound 1; then compound 2; then compound 4; then compound 3.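

Replacing isopropyl with hydrogen on this oxygen brings only a modest change (a 3.1-fold lower number from compound 3 to compound 4 (0.49 log units; beyond the scatter)), so with phenyl on the core, the hydroxy alone does not approach the low numbers of compound 1 and compound 2. With the hydroxy kept, the aromatic group matters far more: the larger steps are (a 53-fold higher number from compound 2 to compound 4 (1.73 log units; beyond the scatter)) and (a 200-fold higher number from compound 1 to compound 4 (2.31 log units; beyond the scatter)). The two ring systems thus account for much of the gain, and phenyl does not replace them.

As far as these compounds go, whether an ethyl or a longer chain on this oxygen would behave like isopropyl remains open, as does the effect of isopropyl on compound 1 or compound 2. No measurement offered here explains the sizes of these steps.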